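This account rests on a few compounds, and the source may have more. Where it says the series, first, only, none or still open, it means among the compounds named here.

Compound 1, `COC(=O)c1cc(-c2cccc(NC(=O)c3ccc(/C=C/C(=O)c4ccccc4)cc3)c2)on1`, gives > 50 ug/mL in an ADME assay on Vero cells (Chlorocebus sabaeus) for cytotoxicity, read by MTT assay, with a stated time of 72 h; a higher number here means that more compound is tolerated, a lower number that less compound is tolerated; this is a limit of the assay, not a number.
Compound 2, `COC(=O)c1cc(-c2cccc(NC(=O)c3ccc(/C=C/C(=O)c4cccc(C(F)(F)F)c4)cc3)c2)on1`, gives > 20 ug/mL in this assay; this too is a limit.
Compound 3, `COC(=O)c1cc(-c2cccc(NC(=O)c3ccc(/C=C/C(=O)c4ccccc4C)cc3)c2)on1`, gives > 25 ug/mL in this assay; again a limit.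

Compound 3 therefore stands only at a limit in this assay, and the two further values shown are limits as well. The steps a step that the two limits leave unreadable from compound 1 to compound 2, a step that the two limits leave unreadable from compound 1 to compound 3 and a step that the two limits leave unreadable from compound 2 to compound 3 cannot be sized, since (the limit of > 20 ug/mL in this assay, at which 1 of the 3 values shown sits), the limit of > 25 ug/mL in this assay, at which 1 of the 3 values shown sits, and the limit of > 50 ug/mL in this assay, at which 1 of the 3 values shown sits, cap each value rather than fix it.

Compound 4, `CCCOc1ccc(C(=O)/C=C/c2ccc(C(=O)Nc3cccc(-c4cc(C(=O)OC)no4)c3)cc2)cc1`, differs from compound 3 in one place: 4-propoxyphenyl in place of 2-methylphenyl on a carbonyl carbon. Among the measured compounds shown here, none of the measured steps gives a readable size that bears on this change, so no direction beyond the scatter can be expected in this assay. Compound 4 is expected to be tolerated much as compound 3 was, and the expected step that the limit leaves unreadable from compound 3 to compound 4 is within the scatter. Compound 4 is estimated at 40 ug/mL in this assay, within 15 ug/mL to 100 ug/mL.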

Compound 4, half-maximal cytotoxic concentration: > 40 ug/mL
Compound 4 gave a limit, no number; the forecaster's own chance of this, stated with the estimate: 70%; the middle value sits exactly at the limit.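

Compound 4 also stops at a limit in this assay, so its steps from compound 1, compound 2 and compound 3 cannot be read. The compounds shown leave open the actual concentration each one tolerates, and whether any of these group changes shifts it.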